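Furan-linked series: aryl group variation at the shared core

The source may hold more compounds than are shown below. What is called first, only, known or untested is meant among the compounds shown, and "the series" means these compounds.

Three measured compounds share one core and differ only in the group on an aromatic carbon. Compound 1 `Cc1cc(C)cc(Cc2ccc3c(NCCCNCc4ccco4)ccnc3c2)c1` gives 6270 nM in an ADME assay on HepG2 cells (Homo sapiens) for cytotoxicity, read by luminescence, CellTiter-Glo and ATP content, with a stated time of 72 h; a lower number here means that less compound is needed, a higher number that more compound is needed for the effect. Compound 2 `COc1cccc(Oc2ccc3c(NCCCNCc4ccco4)ccnc3c2)c1` gives 15500 nM in this assay, and compound 3 `CC(C)(C)c1ccc(-c2ccc3c(NCCCNCc4ccco4)ccnc3c2)cc1` gives 3150 nM in this assay. The steps between them run a 2.5-fold higher number from compound 1 to compound 2 (0.39 log units; beyond the scatter), a 2.0-fold lower number from compound 1 to compound 3 (0.30 log units; within the scatter) and a 4.9-fold lower number from compound 2 to compound 3 (0.69 log units; beyond the scatter). Compound 3 thus holds the lowest of the three numbers; the nearest is compound 1, within the scatter, and the furthest is compound 2, beyond it.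

Compound 4 `COc1ccc(-c2ccc3c(NCCCNCc4ccco4)ccnc3c2)cc1` is not yet measured. It differs from compound 3 by methoxy in place of tert-butyl on an aromatic carbon. Going by the values given here, no measured step exchanges exactly these two groups on the same ring. The closest guide is a 4.9-fold lower number from compound 2 to compound 3 (0.69 log units; beyond the scatter), in which a methoxy-bearing aryl ether gave way to the tert-butylphenyl, together with the narrower a 2.0-fold lower number from compound 1 to compound 3 (0.30 log units; within the scatter). Both suggest that replacing the tert-butyl of compound 3 with a methoxy moves the number up by a modest amount at most, and a step within the scatter cannot be excluded. For compound 4 the expected value in this assay is 5500 nM, with a range from 2500 nM to 13000 nM. The expected step is a 1.7-fold higher number from compound 3 to compound 4 (0.24 log units; within the scatter).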

Compound 4, half-maximal effective concentration: 6000 nM
Compound 4: the middle estimate sits 1.1-fold (0.04 log units) below what was measured, within the range that was stated.
By their numbers in this assay, from the lowest: compounds 3, 4 and 1 (each within the scatter of the next); then compound 2.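

Working notes on the series: the step (a 1.9-fold higher number from compound 3 to compound 4 (0.28 log units; within the scatter)) is the first direct exchange of tert-butyl for methoxy on this phenyl ring, and at this place, para to a large group, it leaves the two compounds within the scatter of each other despite the change from a four-carbon group with no hydrogen-bond acceptor to a smaller group with one. The step (a 2.6-fold lower number from compound 2 to compound 4 (0.41 log units; beyond the scatter)) separates two compounds that both carry a methoxy group, so the presence of methoxy does not by itself place a compound with compound 2, which now stands beyond the scatter from each of the other three compounds. The step (a 1.0-fold lower number from compound 1 to compound 4 (0.02 log units; within the scatter)) shows no separation between the 4-methoxyphenyl and the 3,5-dimethylbenzyl groups, so two different groups at this carbon give values within the scatter of each other.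

Nothing available explains why compound 2 stands apart from the others. Still open, from the compounds shown here alone, is whether an amine or a carboxylic acid in place of the methoxy of compound 4 would give a step beyond the scatter, and whether a longer chain at this place would do so.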